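The compounds below may be only part of what the source reports. "The series", "measured", "known", "first", "only" and "open" are said of these compounds alone.

Working notes on the series. Compound 1 `COc1cccc(CNC(=O)c2cc3ccc(-c4cn[nH]c4)nc3n2CCCO)c1` and compound 2 `COc1cccc(CNC(=O)c2cc3ccc(-c4cn[nH]c4)nc3n2CC2CC2)c1` share one core and differ only in the group on a saturated chain carbon bound to an aromatic nitrogen. In an assay on isolated protein for inhibition of Rho-associated protein kinase 1 (Homo sapiens) (a higher number here means a weaker inhibitor, a lower number a stronger inhibitor), compound 1 gives 88 nM, and compound 2 gives 280 nM; the step of a 3.2-fold higher number from compound 1 to compound 2 (0.50 log units; beyond the scatter) puts compound 2 at the highest number of the two measured.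

Compound 3 `COc1cccc(CNC(=O)c2cc3ccc(-c4cn[nH]c4)nc3n2CCN(C)C)c1` is not yet measured. Its change from compound 2 is (dimethylamino)methyl in place of cyclopropyl on a saturated chain carbon bound to an aromatic nitrogen. Within the data shown here, the only step that bears on it is a 3.2-fold higher number from compound 1 to compound 2 (0.50 log units; beyond the scatter), which shows that replacing the 2-hydroxyethyl group at this position by cyclopropyl raised the number modestly. Compound 3 again carries a group with a hydrogen-bond acceptor at this position, so a return toward the number of compound 1 is expected rather than a further rise.

For compound 3 the expected step is a 2.5-fold lower number from compound 2 to compound 3 (0.41 log units; beyond the scatter), a modest drop. The estimate for compound 3 in this assay is 110 nM, within 35 nM to 350 nM, because compound 1 gives 88 nM with a comparable group at this position.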

Compound 3, half-maximal inhibitory concentration: 243 nM
Beside the measured number, compound 3's estimate is 2.2-fold (0.34 log units) below it, and the stated range covers the measured number.
By their numbers in this assay, from the lowest: compound 1; then compounds 3 and 2 (each within the scatter of the next).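

In this assay, the acceptor-bearing (dimethylamino)methyl group does not separate from cyclopropyl, with a 1.2-fold lower number from compound 2 to compound 3 (0.06 log units; within the scatter), so the hydrogen-bond acceptor counted on the entering group does not by itself restore the number of compound 1. With a 2.8-fold higher number from compound 1 to compound 3 (0.44 log units; beyond the scatter), dimethylamino also fails to stand in for hydroxymethyl on this chain, and of the three compounds only compound 1 stands apart from the others. Nothing available explains these numbers.

Still open, as far as these compounds go, is whether the lower number of compound 1 belongs to the hydroxyl itself or to some wider feature of that chain. A methoxy or primary amine at the end of the same chain, or a longer chain carrying a hydroxyl, would bear on that question.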